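Phenoxyacetamide triazoles: removing the methoxy group

A few compounds are considered here, and "the series" means these few. Any claim that something is new, unique, unknown or untested is made for them only; others in the source may bear on it.

Compound 3 `COc1ccccc1OCC(=O)Nc1nc(-c2ccc(C)cc2)n[nH]1` gives the lowest of the three numbers in an assay on CHO cells for displacement of a labelled ligand from adenosine receptor A3 (Homo sapiens), read by scintillation counting, with a stated time of 60 min (a higher number here means a weaker inhibitor, a lower number a stronger inhibitor), at 1000 nM. Compound 2 `O=C(COc1ccccc1)Nc1nc(-c2ccc(F)cc2)n[nH]1` gives 1500 nM in this assay, and compound 1 `O=C(COc1ccccc1)Nc1nc(-c2ccccc2)n[nH]1` gives 2300 nM; the gap from compound 1 to compound 3 is beyond the scatter, that from compound 2 to compound 3 is not. Compound 4 `Cc1ccc(-c2n[nH]c(NC(=O)COc3ccccc3)n2)cc1` differs from compound 3 by hydrogen in place of methoxy on an aromatic carbon, on an aromatic carbon of a six-membered aromatic ring of carbon only, ortho to a large group; read one bond further out, 2-methoxyphenyl becomes phenyl. For the measured compounds named here, no measured step removes this methoxy; the only measured step, a 1.5-fold lower number from compound 1 to compound 2 (0.19 log units; within the scatter), concerns a fluoro substituent and stays within the scatter. The expected step of a 1.5-fold higher number from compound 3 to compound 4 (0.18 log units; within the scatter) is therefore small, with no direction beyond the scatter assumed. Compound 4 is estimated at 1500 nM, range 600 nM to 4000 nM.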

Compound 4, inhibition constant: 3200 nM
The estimate for compound 4 lay 2.1-fold (0.33 log units) below the measured number; the range from low to high includes it.
By their numbers in this assay, from the lowest: compounds 3, 2, 1 and 4 (each within the scatter of the next, the first and the last beyond it).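

In this assay, hydrogen in place of methoxy gives a 3.2-fold higher number from compound 3 to compound 4 (0.51 log units; beyond the scatter), so this aromatic carbon, ortho to a large group, is sensitive to the change from 2-methoxyphenyl to phenyl. Without the methoxy, methyl in place of fluoro gives a 2.1-fold higher number from compound 2 to compound 4 (0.33 log units; beyond the scatter), whereas methyl in place of hydrogen gives a 1.4-fold higher number from compound 1 to compound 4 (0.14 log units; within the scatter), so the methyl adds no gain over compound 1. No available evidence bears on the reason for these steps.

From the compounds shown here alone, whether ethoxy, hydroxyl or an amine on this carbon would match methoxy remains open. Also open, going by these compounds, is whether the methoxy step carries over to the fluoro-bearing or unsubstituted partners.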